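The compounds below may be only part of what the source reports. "The series", "measured", "known", "first", "only" and "open" are said of these compounds alone.

Working notes on the series. Within the data shown here, compound 1 `CCC/C=C\C(=O)Nc1cc(Nc2nccc(-c3cn(C)c4ccccc34)n2)c(OC)cc1N(C)CCN(C)C` and compound 2 `CC/C=C\C(=O)Nc1cc(Nc2nccc(-c3cn(C)c4ccc(F)cc34)n2)c(OC)cc1N(C)CCN(C)C` differ in two places, so no single step links them; in a functional assay on NCI-H1975 cells (Homo sapiens) for antiproliferative activity, read by MTT assay, with a stated time of 72 h (a lower number here means a stronger inhibitor, a higher number a weaker inhibitor), compound 1 gives 1220 nM, while compound 2 gives 2600 nM. Compound 2 therefore stands at the higher of the two numbers, beyond the scatter from compound 1. Compound 3 `CCC/C=C\C(=O)Nc1cc(Nc2nccc(-c3cn(C)c4ccc(F)cc34)n2)c(OC)cc1N(C)CCN(C)C` follows from compound 2 by methyl in place of hydrogen on a saturated chain carbon, two bonds along the chain from a double-bonded chain carbon. Nothing measured isolates this change, so only a modest step toward a lower number, or none beyond the scatter, is expected from compound 2 to compound 3 a 1.4-fold lower number from compound 2 to compound 3 (0.16 log units; within the scatter). For compound 3 the estimated value in this assay is 1800 nM, in the range 700 nM to 4500 nM.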

Compound 3, half-maximal inhibitory concentration: 2730 nM
Compound 3: middle estimate off by 1.5-fold (0.18 log units), on the low side, within the range that was stated.
By their numbers in this assay, from the lowest: compound 1; then compounds 2 and 3 (each within the scatter of the next).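

In this assay, methyl in place of hydrogen on a saturated chain carbon, two bonds along the chain from a double-bonded chain carbon, gives a 1.1-fold higher number from compound 2 to compound 3 (0.02 log units; within the scatter) and so, with the fluoro present, ethyl to propyl moves nothing beyond the scatter. Fluoro in place of hydrogen on an aromatic carbon gives a 2.2-fold higher number from compound 1 to compound 3 (0.35 log units; beyond the scatter) as the first single-place step beyond the scatter, a modest one. No evidence at hand bears on either step.

Open, as far as these compounds go, is whether a longer chain or an amine at this chain position would move the number. Also open, from the compounds shown here alone, is how chloro in place of the fluoro would read.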